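The source may hold more compounds than are shown below. What is called first, only, known or untested is meant among the compounds shown, and "the series" means these compounds.

Series notes on a set of three measured analogues sharing a common core. Compound 2 `Nc1ccccc1NC(=O)c1ccc(CSC(=S)N2CCCc3ccccc32)cc1` gives 87.5% in a functional assay on MGC-803 cells (Homo sapiens) for antiproliferative activity, read by CCK-8 assay, with a stated time of 72 h, tested at 8 uM (a lower number here means a weaker effect, a higher number a stronger effect of the compound at the concentration tested), and stands at the top of the three numbers, with compound 3 `Nc1ccccc1NC(=O)c1ccc(CSC(=S)N2CCN(c3ccncc3)CC2)cc1` at 87.1% within the scatter of it and compound 1 `Nc1ccccc1NC(=O)c1ccc(CSC(=S)N2CCN(Cc3ccccn3)CC2)cc1` at 65.2% beyond the scatter below it. Compound 4 `CN(Cc1cccnc1)C(=S)SCc1ccc(C(=O)Nc2ccccc2N)cc1` differs from compound 2 by methyl((pyridin-3-yl)methyl)amino in place of 1,2,3,4-tetrahydroquinolin-1-yl on a thiocarbonyl carbon. Within the data shown here, no measured step swaps this exact pair of groups. The nearest guide is a number 21.9 percentage points higher from compound 1 to compound 3 (beyond the scatter), where a pyridinylmethyl on a ring nitrogen gave the weaker number. Compound 4 carries a pyridinylmethyl on the thiocarbonyl nitrogen, so a modest step down is expected in this assay, of a number 15.5 percentage points lower from compound 2 to compound 4 (beyond the scatter). The estimate for compound 4 is therefore 72%, spanning 52% to 88%.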

Compound 4, a percentage reported as inhibition, at one concentration (the size of the read-out at that concentration, not a potency): 85.5%
Compound 4: middle estimate off by 13.5 percentage points, on the low side; measured number inside the range.
By their numbers in this assay, from the lowest: compound 1; then compounds 4, 3 and 2 (each within the scatter of the next).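

In this assay the change on the thiocarbonyl carbon gives a number 2 percentage points lower from compound 2 to compound 4 (within the scatter) and so the position takes an open-chain methyl((pyridin-3-yl)methyl)amino as well as the fused 1,2,3,4-tetrahydroquinolin-1-yl. A non-aromatic ring on this carbon is therefore not required for a number at the level of compound 2. Nothing available explains this tolerance. Open, going by these compounds, is whether a plain dimethylamino or a morpholine ring on the thiocarbonyl carbon holds the number. Also open is whether a benzyl in place of the (pyridin-3-yl)methyl does the same, and a single-concentration read-out cannot separate potencies among these compounds.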